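The source may hold more compounds than are shown below. What is called first, only, known or untested is meant among the compounds shown, and "the series" means these compounds.

Of the compounds shown here, three that share one core have been tested in a functional assay (Sus scrofa) with sulfonylurea receptors; K-ATP channels (Homo sapiens) as the target; on this read-out lower numbers stand for smaller maximal responses and higher numbers for larger maximal responses. Compound 1 `CC(=O)Nc1c(C(O)(C(F)(F)F)C(F)(F)F)ccc2ccccc12` gives 87%, compound 2 `CCCC(=O)Nc1c(C(O)(C(F)(F)F)C(F)(F)F)ccc2ccccc12` gives 92%, and compound 3 `O=C(Nc1c(C(O)(C(F)(F)F)C(F)(F)F)ccc2ccccc12)C1CC1` gives 100%. Compound 2 stands second highest of these three numbers, with its distance to either neighbour inside the usual scatter. Compound 4 `O=C(Nc1c(C(O)(C(F)(F)F)C(F)(F)F)ccc2ccccc12)c1cccc(Cl)c1` has not been measured yet; it differs from compound 2 by 3-chlorophenyl in place of propyl on a carbonyl carbon. Within the data shown here, no measured step trades a chain for an aromatic ring, so the nearest guides are changes at the same carbonyl carbon: a number 8 percentage points higher from compound 2 to compound 3 (within the scatter) and a number 13 percentage points higher from compound 1 to compound 3 (beyond the scatter). Both were small, so only a small movement in this assay is expected, and the expected step is a number 3 percentage points higher from compound 2 to compound 4 (within the scatter). For compound 4 the estimate is 95%, with a range from 75% to 110%.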

Compound 4, largest response reached (reported as efficacy), in percent of the reference or control that the assay uses: 84%
The estimate for compound 4 lay 11 percentage points above the measured number; measured number inside the range.
By their numbers in this assay, from the lowest: compounds 4, 1, 2 and 3 (each within the scatter of the next, the first and the last beyond it).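

In this assay, the first aromatic ring on this carbonyl carbon gives a step inside the scatter against the propyl chain, a number 8 percentage points lower from compound 2 to compound 4 (within the scatter), and against methyl, a number 3 percentage points lower from compound 1 to compound 4 (within the scatter). Cyclopropyl is the only group here that 3-chlorophenyl falls clearly short of, a number 16 percentage points lower from compound 3 to compound 4 (beyond the scatter), so a larger group at this carbon does not by itself go with a larger response. Nothing available explains this gap.

The compounds shown cannot separate the effect of the ring from that of its chlorine. A plain phenyl on the same carbonyl carbon would make that comparison.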